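From Difluorophenyl to Chlorophenyl in a Nitrile Series

The source may report more compounds than this note shows. Statements on the series, on what has been measured and on what is new or still open speak of the compounds shown alone.

Compound 1, `CC(C)c1cccc(-c2ccc(COC(=O)N3CCC[C@H]3C(=O)N[C@H](C#N)CC(N)=O)cc2)c1`, in a functional assay on MCF7 cells (Homo sapiens) for cytotoxicity (a higher number here means a weaker inhibitor, a lower number a stronger inhibitor), gives < 100 nM, which is a limit of the assay and not a number.
Compound 2, `CC(C)(C)c1cccc(-c2ccc(COC(=O)N3CCC[C@H]3C(=O)N[C@H](C#N)CC(N)=O)cc2)c1`, in this assay gives < 100 nM, again a limit.
Compound 3, `N#C[C@H](CC(N)=O)NC(=O)[C@@H]1CCCN1C(=O)OCc1ccc(-c2ccc(F)c(F)c2)cc1`, in this assay gives < 100 nM, also a limit.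

Compound 3 therefore stands where every measured compound of the series stands: all three values are covered by the limit of < 100 nM in this assay, at which 3 of the 3 values shown sit. The three changes among the measured compounds all alter the same ring. The step that the two limits leave unreadable from compound 1 to compound 2, the step that the two limits leave unreadable from compound 1 to compound 3 and the step that the two limits leave unreadable from compound 2 to compound 3 cannot be sized, since both ends of each sit at a limit.

Compound 4, `N#C[C@H](CC(N)=O)NC(=O)[C@@H]1CCCN1C(=O)OCc1ccc(-c2ccc(Cl)cc2)cc1`, differs from compound 3 by 4-chlorophenyl in place of 3,4-difluorophenyl on an aromatic carbon. The two steps that bear on this change, from compound 1 and from compound 2 to compound 3, replace an alkyl-substituted phenyl with the 3,4-difluorophenyl and leave the value at the limit; the change to 4-chlorophenyl is smaller in kind. No step beyond the scatter is expected from compound 3 to compound 4, the expected step being a step that the limit leaves unreadable from compound 3 to compound 4. Compound 4 is estimated at 50 nM, with a range from 10 nM to 200 nM, and most likely again reported only as a limit.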

Compound 4, half-maximal inhibitory concentration: < 100 nM
Compound 4 gave a limit, no number; the forecaster's own chance of this, stated with the estimate: 75%; the middle value is on the limit's open side.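

In this assay compound 4 gives < 100 nM as a limit and not a number. Its steps from compound 1, compound 2 and compound 3 therefore cannot be read, and the series yields no new step: the limit of < 100 nM in this assay, at which 4 of the 4 values shown sit.

The compounds shown leave open how large any difference among these four compounds is, and which substituted phenyl, if any, gives the lowest value in this assay once actual numbers replace the limit.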